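Compound 2 to compound 3: a new group on the carbonyl

The compounds below may be only part of what the source reports. "The series", "measured", "known", "first", "only" and "open" are said of these compounds alone.

Compound 1 `COc1ccc(-c2nc(CN)sc2-c2ccc(OC)cc2)cc1` gives > 100 nM (a limit)
Compound 2 `COc1ccc(-c2nc(CNC(=O)CSc3ccccc3)sc2-c2ccc(OC)cc2)cc1` gives < 100 nM (a limit)
Compound 3 `COc1ccc(-c2nc(CNC(=O)C3=NNC(=O)CC3)sc2-c2ccc(OC)cc2)cc1` is not yet measured

In a functional assay with Oryctolagus cuniculus as the target (a lower number here means a stronger inhibitor, a higher number a weaker inhibitor), compound 2 stands only at a limit (< 100 nM) and carries no number. Among the compounds with values here, the one measured step (a number no higher from compound 1 to compound 2 (the limit leaves the size open)) has no readable size. Compound 3 exchanges the group on the carbonyl carbon (a group of 7 heavy atoms (4 carbon, 2 nitrogen, 1 oxygen; one six-membered non-aromatic ring with 2 hetero atoms) in place of a group of 8 heavy atoms (7 carbon, 1 sulfur; one six-membered aromatic ring of carbon only), on a carbonyl carbon). Within the data shown here, no measured step covers this exchange, so the data give neither a size nor a direction, and no shift beyond the scatter is expected (a step that the limit leaves unreadable from compound 2 to compound 3). Compound 3 is estimated at 50 nM (expected range 10 nM to 250 nM).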

Compound 3, half-maximal inhibitory concentration: 55 nM
The estimate for compound 3 lay 1.1-fold (0.04 log units) below the measured number, within the range that was stated.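

In this assay compound 3 gives 55 nM, the first number rather than a limit for an amide at this carbonyl carbon. Compound 2 carries only a limit, < 100 nM, so the step to compound 3 cannot be read. Putting the full acyl group in place of hydrogen on the amine nitrogen gives an at least 1.8-fold lower number from compound 1 to compound 3 (0.25 log units; that floor lies within the scatter).

As far as these compounds go, whether the (phenylsulfanyl)methyl group and the new ring group differ at all stays open. So does what a carboxylic acid or a plain alkyl chain on this carbonyl carbon would give.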